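Hydroxy to methylamino swap on two cores

The source may report more compounds than this note shows. Statements on the series, on what has been measured and on what is new or still open speak of the compounds shown alone.

Measured in a functional assay on A549 cells (Homo sapiens) for antiproliferative activity, read by MTT assay, with a stated time of 48 h (a higher number here means a weaker inhibitor, a lower number a stronger inhibitor), so far:
compound 1 `COc1ccc(C(=O)c2ccc(OC)c3c2C=CC(C)(C)O3)c(NC(=O)CO)c1` — 100 nM
compound 2 `CNCC(=O)Nc1cc(OC)ccc1C(=O)c1ccc(OC)c2c1C=CC(C)(C)O2` — 1370 nM
compound 3 `COc1ccc(C(=O)c2cc(OC)c(OC)c(OC)c2)c(NC(=O)CO)c1` — 70 nM

Compound 1 and compound 3 carry different cores; how the two cores differ is not broken down here. In this assay compound 3 gives 70 nM and compound 1 gives 100 nM, two numbers within the usual scatter of each other, so no order is drawn between them. Compound 2 stands apart: its step from compound 1, a 14-fold higher number from compound 1 to compound 2 (1.14 log units; beyond the scatter), is beyond the scatter, and its number is also well above that of compound 3.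

The change behind that step is methylamino in place of hydroxy on a saturated chain carbon bound to a carbonyl carbon

Compound 4 `CNCC(=O)Nc1cc(OC)ccc1C(=O)c1cc(OC)c(OC)c(OC)c1` is not yet measured. It relates to compound 3 as compound 2 relates to compound 1: methylamino in place of hydroxy on a saturated chain carbon bound to a carbonyl carbon The place is described in the same words in both pairs, so this is taken as the same change. Going by the values given here, only one earlier instance of it is known, so the expectation rests on that single step. Among the compounds with values here, the step from compound 3 to compound 4 in this assay is expected to be of similar size, a 14-fold higher number from compound 3 to compound 4 (1.15 log units; beyond the scatter), because a 14-fold higher number from compound 1 to compound 2 (1.14 log units; beyond the scatter) is the only measured precedent. On that basis compound 4 is estimated at 1000 nM in this assay, with an expected span from 300 nM to 3500 nM.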

Compound 4, half-maximal inhibitory concentration: 610 nM
The estimate for compound 4 lay 1.6-fold (0.21 log units) above the measured number, within the range that was stated.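

In this assay the change from hydroxy to methylamino, on a saturated chain carbon bound to a carbonyl carbon, gives an 8.7-fold higher number from compound 3 to compound 4 (0.94 log units; beyond the scatter) on the core of compound 3, so the weakening seen on the core of compound 1 appears here as well. The two steps point the same way and their sizes do not separate, so in this series the change carries over from one core to the other as a loss of about the same size: the same change on two cores in this assay, a 14-fold higher number (1.14 log units; beyond the scatter) from compound 1 to compound 2 and an 8.7-fold higher number (0.94 log units; beyond the scatter) from compound 3 to compound 4, 1.6-fold (0.20 log units) apart, within the scatter of two such steps. This rests on one matched pair per core, so it shows agreement on these two cores in this one cell assay only; it does not show that the step would hold on a third core, and it does not say why the change weakens the compounds.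

Still open, going by these compounds, is whether the loss follows the nitrogen itself or its methyl group, which an unsubstituted amine or a dimethylamino group at the same place could separate on both cores. A methoxy group in place of the hydroxy, or a longer chain carrying the hydroxy, would show how far the hydroxy form can be altered before the number moves beyond the scatter.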